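Swapping the Naphthyl Arm for a Methoxyphenyl Group

The source may hold more compounds than are shown below. What is called first, only, known or untested is meant among the compounds shown, and "the series" means these compounds.

Compound 2 `c1ccc2c(-c3cn4ccnc4c(-c4ccc5ncn(C6CCCCC6)c5c4)n3)cccc2c1` stands lowest of the two numbers measured in a functional assay on MDA-MB-468 cells (Homo sapiens) for inhibition, read by sulforhodamine B assay, with a stated time of 48 h, tested at 10 uM (on this read-out lower numbers stand for less inhibition and higher numbers for more inhibition at the one concentration tested (going by the name of the read-out)), where compound 2 gives 10.4%. Among the compounds with values here, its only measured neighbour is compound 1 `Brc1cn2ccnc2c(-c2ccc3ncn(C4CCCCC4)c3c2)n1`, which in this assay gives 44.4%; the one measured step, a number 34 percentage points lower from compound 1 to compound 2 (beyond the scatter), is a large drop when naphthalen-1-yl takes the place of bromo on an aromatic carbon.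

Compound 3 `COc1ccccc1-c1cn2ccnc2c(-c2ccc3ncn(C4CCCCC4)c3c2)n1` has not yet been tested. It differs from compound 2 by 2-methoxyphenyl in place of naphthalen-1-yl on an aromatic carbon. Within the data shown here, no measured step covers an exchange of one aryl group for another, so the step from compound 1 to compound 2 bears on it only indirectly: it shows that placing a naphthalen-1-yl group at this position cut inhibition sharply, and it says nothing about whether a smaller 2-methoxyphenyl group would recover some of that loss. The estimate therefore leans toward a modest rise, as it is expected that a number 9.6 percentage points higher from compound 2 to compound 3 (within the scatter) describes the step to compound 3. Compound 3 is estimated to give 20% in this assay, with a range of 0% to 45%.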

Compound 3, a percentage reported as inhibition, at one concentration (the size of the read-out at that concentration, not a potency): 14.6%
Estimate against measurement, compound 3: 5.4 percentage points above, and the stated range covers the measured number.
By their numbers in this assay, from the lowest: compounds 2 and 3 (each within the scatter of the next); then compound 1.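

In this assay, the exchange of naphthalen-1-yl for 2-methoxyphenyl gives a number 4.2 percentage points higher from compound 2 to compound 3 (within the scatter), so at this aromatic carbon the read-out does not separate these two aryl groups, even though 2-methoxyphenyl has one six-membered aromatic ring of carbon only and 1 hydrogen-bond acceptor, while naphthalen-1-yl has 2 such rings and 0 acceptors. Replacing bromo with 2-methoxyphenyl gives a number 29.8 percentage points lower from compound 1 to compound 3 (beyond the scatter) and is the second aryl exchange for bromo to show a fall beyond the scatter, so the drop seen earlier is no longer tied to naphthalen-1-yl alone, and no listed compound goes against this. The available evidence offers no explanation for this shared fall from bromo.

The compounds shown leave open whether an unsubstituted phenyl ring, an amine or a carboxylic acid at this carbon would stay with compound 2 and compound 3 or move toward compound 1. They also leave open how these compounds compare in potency, as the read-out reflects a single concentration.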